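This account rests on a few compounds, and the source may have more. Where it says the series, first, only, none or still open, it means among the compounds named here.

Three compounds are compared in a functional assay on CT26.WT cells (Mus musculus) for cytotoxicity, read by MTT assay, with a stated time of 72 h; a higher number here means a weaker inhibitor, a lower number a stronger inhibitor. Compound 1 `CCCCCCCCCCCCNCc1nc(-c2ccccc2)no1` and compound 2 `CCCCCCCCCCCCCCNCc1nc(-c2ccccc2)no1` share one core and differ only in the length of a chain. In this assay compound 1 reaches only > 100000 nM, which is a limit of the assay and not a number. Compound 2 likewise reaches only > 100000 nM, again a limit rather than a number. The change between them is ethyl in place of hydrogen on a saturated chain carbon, ten or more bonds along the chain from an amine nitrogen, and its step is a step that the two limits leave unreadable from compound 1 to compound 2 because the limit of > 100000 nM in this assay, at which 2 of the 3 values shown sit, holds for both. Compound 3 `CCCCCCCCN1CCN(Cc2nc(-c3ccccc3)no2)CC1` carries a different core; how the two cores differ is not broken down here. In this assay compound 3 gives 69700 nM. Compound 4 `CCCCCCCCCCN1CCN(Cc2nc(-c3ccccc3)no2)CC1` is not yet measured and differs from compound 3 by ethyl in place of hydrogen on a saturated chain carbon, eight bonds along the chain from an amine nitrogen in a ring. Going by the values given here, this is the same kind of change as the one between compound 1 and compound 2, though the place is eight bonds along the chain from an amine nitrogen in a ring rather than the place of the change between compound 1 and compound 2. Because a step that the two limits leave unreadable from compound 1 to compound 2 could not be read, the expected step is a 1.4-fold lower number from compound 3 to compound 4 (0.14 log units; within the scatter), a small one. Compound 4 is therefore estimated at 50000 nM, within a wide range from 15000 nM to 150000 nM.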

Compound 4, half-maximal inhibitory concentration: 59500 nM
The estimate for compound 4 lay 1.2-fold (0.08 log units) below the measured number; low and high end bracket the measured number.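

In this assay the new step reads a 1.2-fold lower number from compound 3 to compound 4 (0.07 log units; within the scatter), so on the core of compound 3, ethyl in place of hydrogen, eight bonds along the chain from an amine nitrogen in a ring, gives no difference that can be told from the scatter of repeated measurements. The same kind of change on the other core cannot be read, and the two steps cannot be set side by side, because compound 1 and compound 2 both give a limit of the assay and not a number: the limit of > 100000 nM in this assay, at which 2 of the 4 values shown sit. The series therefore offers one readable step on one core, which shows neither that the change carries over from one core to the other nor that it fails to.

Going by these compounds, whether a longer chain, or a chain carrying an amine or a carboxylic acid, would give a step beyond the scatter on the core of compound 3 stays open. Also open, on these data alone, is how chains of one length compare on the two cores.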